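Swapping an Unsaturated Amine Chain for a Longer Saturated One

The compounds below may be only part of what the source reports. "The series", "measured", "known", "first", "only" and "open" are said of these compounds alone.

compound 1 `NCCCCN(C[C@@H]1Cc2ncccc2CN1)[C@H]1CCCc2cccnc21` — in an ADME assay on microsomes from liver (Mus musculus) for metabolic stability, using NADPH, with a stated time of 10 min (a lower number here means that less of the compound is left, a higher number that more of the compound is left), compound 1 gives 75%
compound 2 `CN(C[C@@H]1Cc2ncccc2CN1)[C@H]1CCCc2cccnc21` — in this assay compound 2 gives 0%
compound 3 `NC/C=C/CN(C[C@H]1Cc2ncccc2CN1)[C@H]1CCCc2cccnc21` — in this assay compound 3 gives 37%

Compound 3 stands second highest of the three numbers: compound 2 lies well below it and compound 1 well above it, both gaps beyond the scatter. Compound 4 `c1cnc2c(c1)CN[C@@H](CN(CCCCNC1CCOCC1)[C@H]1CCCc3cccnc31)C2` differs from compound 3 in one place: 3-((oxan-4-yl)amino)propyl in place of 3-aminoprop-1-en-1-yl on a saturated chain carbon bound to an amine nitrogen. Within the data shown here, the only measured step that bears on this position is a number 75 percentage points lower from compound 1 to compound 2 (beyond the scatter), in which the amine-bearing chain on that nitrogen was replaced by hydrogen and almost nothing of the compound survived. Compound 4 keeps such a chain, now as 3-((oxan-4-yl)amino)propyl. Among the measured compounds shown here, compound 1, whose chain is also saturated, gives the higher of the two numbers when set beside compound 3, though no measured step connects those two directly. For the measured compounds named here, the change from compound 3 to compound 4 is therefore expected to raise the number, by about a number 18 percentage points higher from compound 3 to compound 4 (beyond the scatter), but the added ring has no measured precedent here, so the range must be wide. Compound 4 is expected to give 55%, between 25% and 85%.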

Compound 4, percent of the compound remaining: 35%
Compound 4: the middle estimate sits 20 percentage points above what was measured; measured number inside the range.
By their numbers in this assay, from the lowest: compound 2; then compounds 4 and 3 (each within the scatter of the next); then compound 1.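

In this assay, exchanging the amine-bearing chain gives a number 2 percentage points lower from compound 3 to compound 4 (within the scatter) with no change that can be told from the scatter, so at this position a larger group carrying a six-membered non-aromatic ring can take the place of the smaller open chain with no readable effect on the amount of compound left. The new value also adds to what compound 1 showed: compound 1 gives 75% and compound 4 gives 35%, so a chain without a double bond does not by itself bring the number up to that of compound 1 when the chain amine carries the oxan-4-yl ring. No measurement at hand explains why compound 3 and compound 4 give numbers so much alike.

On these data alone, it stays open whether the ring oxygen matters, which a cyclohexyl group on the chain amine would help to show. As far as these compounds go, it also stays open how a chain ending in a carboxylic acid or an amide in place of the amine would fare at this position.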